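The source may report more compounds than this note shows. Statements on the series, on what has been measured and on what is new or still open speak of the compounds shown alone.

Compound 1 `C/C(=N\C#N)N(Cc1ccc(Cl)nc1)C(C)C` is the reference point here. In a physicochemical assay for lipophilicity, read by HPLC, using the shake flask method (on this read-out higher numbers stand for higher lipophilicity and lower numbers for lower lipophilicity), compound 1 gives 1.46 as the lowest of three numbers. Compound 2 `CCCCC/C(=N\C#N)N(C)Cc1ccc(Cl)nc1` reads 2.3 and compound 3 `CCCC/C(=N\C#N)N(C)Cc1ccc(Cl)nc1` reads 1.87 on the same scale. Compound 4 `C=CCN(Cc1ccc(Cl)nc1)/C(C)=N/C#N` is still unmeasured and has allyl in place of isopropyl on an amine nitrogen with carbons matched. Among the measured compounds shown here, the one measured step that bears on this is a number 0.43 log units lower from compound 2 to compound 3 (beyond the scatter) with hydrogen in place of methyl on a saturated chain carbon. No carbon is lost in this change, so a smaller step than a number 0.43 log units lower from compound 2 to compound 3 (beyond the scatter) is expected in this assay and probably a downward one. The expected step is a number 0.26 log units lower from compound 1 to compound 4 (within the scatter) by this estimate. Compound 4 is estimated at 1.2 with a range from 0.9 to 1.5 overall.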

Compound 4, partition coefficient: 1.56
Compound 4: middle estimate off by 0.36 log units, on the low side; measured number outside the range, above it.
By their numbers in this assay, from the lowest: compounds 1 and 4 (each within the scatter of the next); then compound 3; then compound 2.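

In this assay, allyl in place of isopropyl on an amine nitrogen gives a number 0.10 log units higher from compound 1 to compound 4 (within the scatter). Among the compounds shown here, the one earlier step removed a carbon from a chain; this one keeps the three carbons and adds a double bond outside aromatic rings, and the two numbers stay within the scatter of each other. No measured evidence here accounts for this result.

Still open, from the compounds shown here alone, is how a longer chain, a benzyl group or a chain carrying a hydroxyl group would read at this amine nitrogen. Whether allyl and isopropyl also read alike on a different core is open too.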